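Removing one anilino nitrogen from a shared core

The compounds below may be only part of what the source reports. "The series", "measured", "known", "first", "only" and "open" are said of these compounds alone.

Measured so far in a functional assay on MDA-MB-435 cells (Homo sapiens) for inhibition, read by sulforhodamine B assay, with a stated time of 48 h, tested at 0.01 uM; a higher number here means a weaker effect of the compound at the concentration tested, a lower number a stronger effect:
compound 1 `COc1cc(Cl)cc(-c2nn(-c3cccc(NC(=O)Nc4ccc(Cl)c(C(F)(F)F)c4)c3)cc2-c2ccncc2)c1` gives 95%
compound 2 `COc1cc(Cl)cc(-c2nn(-c3cccc(NC(=O)Nc4cccc(C(F)(F)F)c4)c3)cc2-c2ccncc2)c1` gives 100%

Both numbers sit near the top of the scale, which means that at the tested concentration neither compound does much to the cells. Compound 2 holds the higher of the two numbers, with compound 1 nearest; the step of a number 5 percentage points higher from compound 1 to compound 2 (within the scatter) is within the scatter, so no real difference between the two compounds can be claimed.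

Compound 3 `COc1cc(Cl)cc(-c2nn(-c3cccc(NC(=O)c4cccc(C(F)(F)F)c4)c3)cc2-c2ccncc2)c1` has not been measured. It differs from compound 2 in one place: 3-(trifluoromethyl)phenyl in place of (3-(trifluoromethyl)phenyl)amino on a carbonyl carbon. Going by the values given here, the only measured step, from compound 1 to compound 2, concerns a different part of the molecules, a hydrogen in place of chloro on an aromatic carbon, and it was a number 5 percentage points higher from compound 1 to compound 2 (within the scatter). Among the compounds with values here, it therefore says nothing about losing the amino group on the carbonyl carbon, and no measured step bears on this change.

With both known compounds showing little effect, compound 3 is expected to stay in the same region; the step of a number 2 percentage points lower from compound 2 to compound 3 (within the scatter) is expected to be within the scatter. The estimate for compound 3 is 98%, with a range from 85% to 110%.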

Compound 3, a percentage reported as activity, at one concentration (the size of the read-out at that concentration, not a potency): 98%
Compound 3: the middle estimate sits on the measured number at the digits printed; low and high end bracket the measured number.
By their numbers in this assay, from the lowest: compounds 1, 3 and 2 (each within the scatter of the next).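

In this assay, removing the amino nitrogen from the group on the carbonyl carbon gives a step within the scatter, a number 2 percentage points lower from compound 2 to compound 3 (within the scatter), and the same holds when the comparison starts from the chloro-bearing compound, a number 3 percentage points higher from compound 1 to compound 3 (within the scatter). The earlier pair spoke only to a chloro group on the outer aromatic ring, whereas these steps show that, at this single concentration, (3-(trifluoromethyl)phenyl)amino and 3-(trifluoromethyl)phenyl on this carbonyl carbon cannot be told apart, even though only the first carries a hydrogen-bond donor. No experimental information explains this outcome.

All three compounds sit near the top of the scale, where little effect is seen, so this result cannot show whether the amino group would matter in a compound with a clear effect on the cells. Also open, from the compounds shown here alone, is how a methylene group, a sulfonyl group or a plain phenyl ring without trifluoromethyl would behave at this place, and whether any of them would give a lower number in this assay.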